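Swapping phenyl for but-3-yn-1-yl in a growth inhibitor

A few compounds are considered here, and "the series" means these few. Any claim that something is new, unique, unknown or untested is made for them only; others in the source may bear on it.

- compound 1 `CCOC(=O)/C(C)=C/C1=CC[C@H]2C(C)(C)CCC[C@]2(C)[C@H]1C=O` gives 27000 nM
- compound 2 `CC1(C)CCC[C@]2(C)[C@@H](C=O)C(/C=C/C(=O)OCc3ccccc3)=CC[C@@H]12` gives 27000 nM

Both values come from a functional assay on MCF7 cells (Homo sapiens) for inhibition, read by MTT assay, with a stated time of 72 h (a higher number here means a weaker inhibitor of growth, a lower number a stronger inhibitor of growth), and place compound 2 level with compound 1, within the usual scatter of repeated measurements. Compound 3 `C#CCCCOC(=O)/C=C/C1=CC[C@H]2C(C)(C)CCC[C@]2(C)[C@H]1C=O` has not been measured yet. It differs from compound 2 by but-3-yn-1-yl in place of phenyl on a saturated chain carbon bound to an oxygen next to a carbonyl group. Compound 1 and compound 2 share 27000 nM in this assay and so offer no hint of a direction. The expected size is no change at the digits printed from compound 2 to compound 3 (within the scatter) with nothing estimated beyond the scatter. The expected value for compound 3 is 27000 nM with an estimated range from 11000 nM to 60000 nM as the likely span.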

Compound 3, concentration for 50% growth inhibition: 30000 nM
Compound 3: the middle estimate sits 1.1-fold (0.05 log units) below what was measured; low and high end bracket the measured number.
By their numbers in this assay, from the lowest: compounds 1, 2 and 3 (each within the scatter of the next).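

In this assay, putting but-3-yn-1-yl in place of phenyl on a saturated chain carbon bound to an oxygen next to a carbonyl group gives a 1.1-fold higher number from compound 2 to compound 3 (0.05 log units; within the scatter). At this place, then, the aromatic ring can give way to an open chain ending in a triple bond with no step beyond the scatter. This single pair cannot show whether other groups at this place would be tolerated as well.

As far as these compounds go, whether an amine or a carboxylic acid on this chain would shift the number remains open. Nothing available explains why phenyl and but-3-yn-1-yl read alike.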